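The source may report more compounds than this note shows. Statements on the series, on what has been measured and on what is new or still open speak of the compounds shown alone.

Measured compounds in a physicochemical assay for solubility, in phosphate buffer, measured as kinetic solubility, at pH 7.4; on this read-out higher numbers stand for higher solubility and lower numbers for lower solubility:
- compound 1 `Cc1oc(-c2ccc(Cl)cc2)nc1CN1CCC(C(=O)NCCCN2C[C@H](C)C[C@H](C)C2)CC1` gives > 72 ug/mL, a limit of the assay.
- compound 2 `Cc1ccccc1-c1nc(CN2CCC(C(=O)NCCCN3CCC(C)CC3)CC2)c(C)o1` gives > 67 ug/mL, a limit of the assay.
- compound 3 `Cc1ccccc1-c1nc(CN2CCC(C(=O)NCCCN3CCCCC3)CC2)c(C)o1` gives > 65 ug/mL, a limit of the assay.

Compound 1 stands at a limit, as do the other two values; none of the three is a number. Within the data shown here, the only single-point step, a step that the two limits leave unreadable from compound 2 to compound 3, runs between two limits and its size is not readable.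

Compound 4 `Cc1ccc(-c2nc(CN3CCC(C(=O)NCCCN4C[C@H](C)C[C@H](C)C4)CC3)c(C)o2)cc1C` differs from compound 1 by 3,4-dimethylphenyl in place of 4-chlorophenyl on an aromatic carbon. Among the measured compounds shown here, no measured step touches this change, and the one step known gives no readable size. The expectation for this assay therefore rests on compound 1 sitting at the limit of > 72 ug/mL in this assay, at which 1 of the 3 values shown sits: the step of an at least 1.0-fold lower number from compound 1 to compound 4 (0.01 log units; that floor lies within the scatter) is expected to be none beyond the scatter. Compound 4 is estimated at 70 ug/mL, range 35 ug/mL to 140 ug/mL, most likely reported again only as a limit.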

Compound 4, solubility: > 71 ug/mL
Compound 4 ended at the assay's limit; the forecaster's own chance of this, stated with the estimate: 70%; at least 1.0-fold (0.00 log units) between middle value and limit.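

In this assay, compound 1 and compound 4 both stand at limits of the assay, so the step between them cannot be read. As far as these compounds go, whether 3,4-dimethylphenyl in place of 4-chlorophenyl changes the read-out at all remains open.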